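A Second Methoxy Group: What to Expect

The source may hold more compounds than are shown below. What is called first, only, known or untested is meant among the compounds shown, and "the series" means these compounds.

Within the data shown here, compound 1 `COc1ccccc1Sc1c[nH]c2ccc(Cl)cc12` gives 17500 nM in an assay on isolated protein for inhibition of Indoleamine 2,3-dioxygenase 1 (Homo sapiens), read by HPLC, with a stated time of 60 min, in the presence of a further agent that is not named here (on this read-out lower numbers stand for stronger inhibition and higher numbers for weaker inhibition), the lower of the two numbers so far; compound 2 `COc1ccccc1Sc1c[nH]c2ccc(I)cc12` gives 45000 nM, and a 2.6-fold higher number from compound 1 to compound 2 (0.41 log units; beyond the scatter). Compound 3 `COc1ccc(Sc2c[nH]c3ccc(Cl)cc23)c(OC)c1` differs from compound 1 by methoxy in place of hydrogen on an aromatic carbon. Among the measured compounds shown here, the only measured step, from compound 1 to compound 2, swaps one halogen for another on the shared core and so offers no guide to adding a methoxy group; no measured step bears on this change. Compound 3 is therefore expected to sit near compound 1, and the expected step of no change at the digits printed from compound 1 to compound 3 (within the scatter) lies within the scatter. The estimate for compound 3 is 17500 nM, with a range from 6000 nM to 50000 nM.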

Compound 3, half-maximal inhibitory concentration: > 50000 nM
Compound 3: no number, only a limit; the forecaster's own chance of this, stated with the estimate: 10%; at least 2.8-fold (0.45 log units) between middle value and limit.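

Putting methoxy in place of hydrogen at this place, meta to a methoxy group and para to a large group, gives an at least 2.8-fold higher number from compound 1 to compound 3 (0.45 log units; beyond the scatter). Among these compounds, this is the first sign that the change weakens inhibition here rather than leaving it unchanged. Compound 3 sits at a limit and not at a number, so the step shows only its smallest possible size: the limit of > 50000 nM in this assay, at which 1 of the 3 values shown sits.

From the compounds shown here alone, whether fluoro, hydroxyl or an amine at this place would also raise the number stays open. So does whether methoxy here would act the same way with iodo in place of chloro.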